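Second Methyl Removed from an Aromatic Oxygen

This account rests on a few compounds, and the source may have more. Where it says the series, first, only, none or still open, it means among the compounds named here.

Compound 1 `COc1ccc2[nH]c(-c3ccc(F)cc3)cc(=O)c2c1OC` in a functional assay on Hep 3B2 cells (Homo sapiens) for cytotoxicity, read by MTT assay, with a stated time of 48 h (on this read-out lower numbers stand for stronger inhibition and higher numbers for weaker inhibition), gives only a limit of the assay, > 20000 nM.
Compound 2 `COc1ccc2[nH]c(-c3ccc(F)cc3)cc(=O)c2c1O` in this assay gives 11000 nM.

Compound 2 thus holds the only number shown; the other value is a limit (the limit of > 20000 nM in this assay, at which 1 of the 2 values shown sits). Compound 3 `O=c1cc(-c2ccc(F)cc2)[nH]c2ccc(O)c(O)c12` differs from compound 2 by hydrogen in place of methyl on an oxygen on an aromatic ring. Going by the values given here, the single measured step of the same kind, an at least 1.8-fold lower number from compound 1 to compound 2 (0.25 log units; that floor lies within the scatter), bears on it, and its floor lies within the scatter. A modest downward step in this assay is therefore expected, though not one clearly beyond the scatter. Compound 3 is estimated at 6500 nM, within 2500 nM to 20000 nM. That estimate means an expected step of a 1.7-fold lower number from compound 2 to compound 3 (0.23 log units; within the scatter).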

Compound 3, half-maximal inhibitory concentration: 100000 nM
Compound 3: middle estimate off by 15-fold (1.19 log units), on the low side; measured number outside the range, above it.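

At this oxygen, the change from methoxy to hydroxy gives a 9.1-fold higher number from compound 2 to compound 3 (0.96 log units; beyond the scatter) in this assay, so the downward direction suggested by the first removal does not carry over to the remaining methoxy. The earlier step gave only a floor, since compound 1 stands at a limit of the assay: the limit of > 20000 nM in this assay, at which 1 of the 3 values shown sits.

The compounds shown leave open whether an ethoxy group or an amine in this place would give a number nearer that of compound 2 or that of compound 3. They also leave open how a longer chain on this oxygen would read.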